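Compound 2 to compound 3: one group exchanged

The source may hold more compounds than are shown below. What is called first, only, known or untested is meant among the compounds shown, and "the series" means these compounds.

Compound 1 `CN(C)c1ccc(/C=C(/Sc2ccccc2Br)C(=O)c2ccc(Br)cc2)cc1`: > 100000 nM (a limit of the assay, not a number)
Compound 2 `CN(C)c1ccc(/C=C(/SCc2ccc(F)cc2)C(=O)c2ccc(Br)cc2)cc1`: 50000 nM

Both compounds were tested in a functional assay on DU-145 cells (Homo sapiens) for inhibition, read by trypan blue exclusion, with a stated time of 96 h; a higher number here means a weaker inhibitor of growth, a lower number a stronger inhibitor of growth. For the measured compounds named here, compound 2 gives the only actual number at 50000 nM. The result for compound 1 is a limit.

Compound 3 `Cc1ccsc1/C=C(/SCc1ccc(F)cc1)C(=O)c1ccc(Br)cc1` keeps the 4-fluorobenzyl on the sulfur of compound 2 but exchanges another group: 3-methylthiophen-2-yl in place of 4-(dimethylamino)phenyl on a double-bonded chain carbon bound to a double-bonded chain carbon.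

Going by the values given here, the only measured step is an at least 2.0-fold lower number from compound 1 to compound 2 (0.30 log units; that floor lies within the scatter) and it concerns the group on a sulfur. Among the compounds with values here, no measured step touches the 4-(dimethylamino)phenyl group, so none shows how large this exchange may be. The expectation therefore rests on compound 2 and its 50000 nM alone. No step beyond the scatter is expected in this assay, in either direction, but the uncertainty is wide. Compound 3 could also end at the limit of > 100000 nM in this assay, at which 1 of the 2 values shown sits, and give no number.

Compound 3 is estimated at 50000 nM with an expected range from 15000 nM to 100000 nM as the concentration for half growth inhibition. This estimate means an expected no change at the digits printed from compound 2 to compound 3 (within the scatter) and so no change beyond the scatter.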

Compound 3, concentration for 50% growth inhibition: 50000 nM
The estimate for compound 3 equals the measured number at the digits printed; the range from low to high includes it.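

In this assay, 3-methylthiophen-2-yl in place of 4-(dimethylamino)phenyl gives no change at the digits printed from compound 2 to compound 3 (within the scatter). For the compounds shown here, this is the first measured step at this place, on a double-bonded chain carbon bound to a double-bonded chain carbon, as the earlier step concerned only the group on a sulfur. With the 4-fluorobenzyl on the sulfur kept, the read-out therefore does not depend on the dimethylamino nitrogen or on a six-membered aromatic ring of carbon only, since a five-membered aromatic ring with 1 hetero atom and 6 heavy atoms instead of 9 leaves compound 3 at 50000 nM.

This single exchange does not show whether any group at this place can give a lower number beyond the scatter, and a 4-carboxyphenyl group or a phenyl ring carrying a longer aminoalkyl chain would test that more widely. Compound 1 marks how little room remains for reading a weaker compound in this series, because its result is a limit and not a number: the limit of > 100000 nM in this assay, at which 1 of the 3 values shown sits.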